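The source may report more compounds than this note shows. Statements on the series, on what has been measured and on what is new or still open speak of the compounds shown alone.

Working notes on the series. Within the data shown here, compound 1 `CC(C)c1onc(-c2c(Cl)cccc2Cl)c1COc1ccc(-c2nc3ccc(C(=O)O)cc3n2C(C)C)cc1` is the only member with a number: in an assay on isolated protein for agonist activity at Bile acid receptor (Homo sapiens), read by TR-FRET (on this read-out lower numbers stand for an effect already at smaller amounts and higher numbers for an effect only at larger amounts of compound), compound 1 gives 56.7 nM. Compound 2 `CC(=O)N1CCC(n2c(-c3ccc(OCc4c(-c5c(Cl)cccc5Cl)noc4C(C)C)cc3)nc3ccc(C(=O)O)cc32)CC1` has no result in this assay; the entry for compound 2 reads "not determined" (no result reported). Among the measured compounds shown here, compound 3 `CC(C)c1onc(-c2c(Cl)cccc2Cl)c1COc1ccc(-c2nc3ccc(C(=O)O)cc3n2C2CCC2)cc1` likewise has no result in this assay, the entry for compound 3 reading "not determined" (no result reported), so compound 3 stands nowhere on the numbers; it is one of two entries without a single value, and no step between any two measured compounds can be drawn from what is at hand.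

The step of interest goes from compound 3 to compound 4 `CCCn1c(-c2ccc(OCc3c(-c4c(Cl)cccc4Cl)noc3C(C)C)cc2)nc2ccc(C(=O)O)cc21`, which has yet to be run in this assay. The change is propyl in place of cyclobutyl on an aromatic nitrogen. For the measured compounds named here, with no measured step in this assay to lean on, and with compound 1 as the only anchor at 56.7 nM, the expectation is that compound 4 lands in the same region as compound 1, with no step beyond the usual scatter in either direction. Compound 4 is thus estimated at 70 nM in this assay, within a range from 25 nM to 200 nM.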

Compound 4, half-maximal effective concentration: 96.4 nM
The estimate for compound 4 lay 1.4-fold (0.14 log units) below the measured number, and the stated range covers the measured number.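

Among these compounds, the first readable step at this position in this assay is a 1.7-fold higher number from compound 1 to compound 4 (0.23 log units; within the scatter), with propyl in place of isopropyl on the aromatic nitrogen, so on this read-out the two chains cannot be told apart. A number in this region therefore holds for both the branched and the unbranched group, while the steps involving cyclobutyl or the other ring-bearing substituent cannot be read, as neither compound 2 nor compound 3 has a single number. No measurement at hand accounts for the result.

As far as these compounds go, whether a ring on this nitrogen keeps the number in the same region stays open. Also open, from the compounds shown here alone, is how a longer chain, such as butyl or hexyl, or a chain ending in an amine or a hydroxyl group would read at this position.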